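Trimethoxyphenyl series: aryl replacement on the fused core

This account rests on a few compounds, and the source may have more. Where it says the series, first, only, none or still open, it means among the compounds named here.

Measured so far in a functional assay on A549 cells (Homo sapiens) for inhibition, read by CCK-8 assay, with a stated time of 48 h; on this read-out higher numbers stand for weaker inhibition and lower numbers for stronger inhibition:
- compound 1 `COc1cc(-c2ccnc3cc(-c4ccc(C(F)(F)F)cc4)nn23)cc(OC)c1OC`: 2070 nM
- compound 2 `COc1cc(-c2ccnc3cc(-c4cccc5c4ccn5CO)nn23)cc(OC)c1OC`: 1100 nM
- compound 3 `CCOC(=O)c1ccc(-c2cc3nccc(-c4cc(OC)c(OC)c(OC)c4)n3n2)cc1`: reported only as a limit, > 10000 nM

Compound 1 gives the higher of the two numbers in this assay; compound 2 sits lower, but the gap between compound 1 and compound 2 is within the scatter, so no order can be read from it. The value for compound 3 is a limit of this assay, not a number. Among the measured compounds shown here, the one step measured at this position, an at least 4.8-fold higher number from compound 1 to compound 3 (0.68 log units; beyond the scatter), is the only direct guide; its size is bounded by the limit of > 10000 nM in this assay, at which 1 of the 3 values shown sits.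

Compound 4 `COc1ccc(-c2cc3nccc(-c4cc(OC)c(OC)c(OC)c4)n3n2)cc1N` is not yet measured. It differs from compound 1 by 3-amino-4-methoxyphenyl in place of 4-(trifluoromethyl)phenyl on an aromatic carbon. For the measured compounds named here, the only measured change at this carbon, compound 1 to compound 3, weakened inhibition, but that step swapped in a different group, so it carries little weight here. For compound 4 a step of about a 1.2-fold higher number from compound 1 to compound 4 (0.08 log units; within the scatter) is expected, roughly flat against compound 1 and not beyond the scatter. Compound 4 is estimated at 2500 nM, with a range from 600 nM to 10000 nM.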

Compound 4, half-maximal inhibitory concentration: 138 nM
Estimate against measurement, compound 4: 18-fold (1.26 log units) above; the whole stated range lies above it.
By their numbers in this assay, from the lowest: compound 4; then compounds 2 and 1 (each within the scatter of the next). At a limit, above all of these: compound 3.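

In this assay, among the compounds shown here, the aryl group on this carbon of the shared core can strengthen inhibition as well as weaken it: the change gives a 15-fold lower number from compound 1 to compound 4 (1.18 log units; beyond the scatter), whereas the only earlier step here went toward weaker inhibition. The entering 3-amino-4-methoxyphenyl carries a hydrogen-bond donor and acceptors and the leaving 4-(trifluoromethyl)phenyl carries neither, but the swap replaces both the substituents and their placement on the ring at once, so no single feature can be credited with the step. Nothing measured here accounts for its size.

Still open, from the compounds shown here alone, is whether the amine or the methoxy carries the gain, which an aryl group bearing only one of them would separate. Also open, going by these compounds, is whether a hydroxyl or an acetamide could stand in place of the amine.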